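A fluoro group on the phenyl of compound 2

This account rests on a few compounds, and the source may have more. Where it says the series, first, only, none or still open, it means among the compounds named here.

Of the compounds shown here, two sharing one core have been measured so far in an ADME assay on microsomes from liver (Mus musculus) for metabolic stability, with a stated time of 10 min, tested at 0.5 uM; on this read-out higher numbers stand for a more stable compound and lower numbers for a less stable compound. Compound 1 (`Cc1noc(C)c1[C@@H]1C[C@@](C)(c2ccc(F)cc2F)N=C(N)S1`), which carries fluorine on its aromatic ring, gives 72%. Compound 2 (`Cc1noc(C)c1[C@@H]1C[C@@](C)(c2ccccc2)N=C(N)S1`), with a plain phenyl in that place, gives 78%. These two numbers lie within the usual scatter of each other, so compound 2 stands level with compound 1.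

Compound 3 (`Cc1noc(C)c1[C@@H]1C[C@@](C)(c2ccc(F)cc2)N=C(N)S1`) differs from compound 2 in one place: fluoro in place of hydrogen on an aromatic carbon. Fluoro takes the place of hydrogen on an aromatic carbon, para to a large group, which turns phenyl to 4-fluorophenyl. Among the measured compounds shown here, no measured pair shows this change on its own, so its size cannot be read directly. The nearest guide is compound 1 at 72%, which has fluorine on the ring and still lies within the scatter of compound 2. A small downward step of a number 3 percentage points lower from compound 2 to compound 3 (within the scatter) is therefore expected, one that stays within the scatter. For compound 3 the estimated value is 75%, with an expected range of 63% to 86%.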

Compound 3, percent of the compound remaining: 90%
Estimate against measurement, compound 3: 15 percentage points below; measured number above the stated range.
By their numbers in this assay, from the lowest: compounds 1 and 2 (each within the scatter of the next); then compound 3.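

With fluoro in place of hydrogen on an aromatic carbon, para to a large group, this assay gives a number 12 percentage points higher from compound 2 to compound 3 (beyond the scatter), so the 4-fluorophenyl stands apart from the plain phenyl in a way the earlier pair could not show. The further fluoro of compound 1 counts against the number: putting hydrogen in its place gives a number 18 percentage points higher from compound 1 to compound 3 (beyond the scatter), which shows that on this ring a single fluoro can raise the number while a second one lowers it, so the effect of fluoro depends on which carbon carries it. Nothing at hand accounts for either step.

The compounds shown hold only hydrogen and fluoro at the para carbon, so it stays open whether the rise is particular to fluoro or would also come with chloro, methoxy, a nitrile or an amine there. Also open, from the compounds shown here alone, is what a lone fluoro would do on the other fluorinated carbon of compound 1, and whether either step would hold with a different group in place of the methyl on the shared core.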